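Amide-to-urea swap on the chloro-methoxyphenyl pyrazole series

The compounds below may be only part of what the source reports. "The series", "measured", "known", "first", "only" and "open" are said of these compounds alone.

Compound 1 `COc1cc(-c2nn(-c3cccc(NC(=O)c4cccc(C(F)(F)F)c4)c3)cc2-c2ccncc2)ccc1Cl` carries a 3-(trifluoromethyl)phenyl amide and in a functional assay on SK-OV-3 cells (Homo sapiens) for inhibition, read by sulforhodamine B assay, with a stated time of 48 h (a lower number here means a stronger inhibitor of growth, a higher number a weaker inhibitor of growth), gives 2290 nM, the highest number among the three measured compounds. Among the measured compounds shown here, compound 2 `COc1cc(-c2nn(-c3cccc(NC(=O)c4ccccc4)c3)cc2-c2ccncc2)ccc1Cl` gives 1070 nM, and the step of a 2.1-fold lower number from compound 1 to compound 2 (0.33 log units; beyond the scatter) is the only single-point change available. Compound 3 `O=C(Nc1cccc(-n2cc(-c3ccncc3)c(-c3ccc(Cl)c(O)c3)n2)c1)Nc1ccc(Cl)c(C(F)(F)F)c1`, a urea on a hydroxy rather than methoxy core, gives 1340 nM, a number within the scatter of compound 1.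

Compound 4 `COc1cc(-c2nn(-c3cccc(NC(=O)Nc4ccc(Cl)c(Cl)c4)c3)cc2-c2ccncc2)ccc1Cl` differs from compound 1 by (3,4-dichlorophenyl)amino in place of 3-(trifluoromethyl)phenyl on a carbonyl carbon. For the measured compounds named here, no measured step covers an amide-to-urea change on this core; the step from compound 1 to compound 2 concerns only the trifluoromethyl group and points toward lower numbers when the ring is simplified, while compound 3 shows a dichloro-type urea giving a number close to compound 1. The expected step of a 1.5-fold lower number from compound 1 to compound 4 (0.18 log units; within the scatter) is therefore small, likely within the scatter or a modest lowering. Compound 4 is estimated at 1500 nM, with a range from 600 nM to 4000 nM.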

Compound 4, concentration for 50% growth inhibition: 1930 nM
For compound 4 the middle estimate is 1.3-fold (0.11 log units) below the measured one, within the range that was stated.
By their numbers in this assay, from the lowest: compounds 2, 3, 4 and 1 (each within the scatter of the next, the first and the last beyond it).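

On a carbonyl carbon, (3,4-dichlorophenyl)amino in place of 3-(trifluoromethyl)phenyl gives a step in this assay (a 1.2-fold lower number from compound 1 to compound 4 (0.07 log units; within the scatter)) that does not separate the urea from the substituted amide on this core. In place of phenyl, the same group also stays within the scatter (a 1.8-fold higher number from compound 2 to compound 4 (0.26 log units; within the scatter)), so compound 4 cannot be separated from either amide, even though those two amides differ beyond the scatter. Nothing available explains these steps.

The urea link and the ring substituents change together in both steps, so a plain phenylamino group on the same carbonyl carbon would be needed to read them apart. On these data alone, whether the urea hydrogen matters remains open, and an N-methyl urea or a cyclohexylamino group at this place would test the point further.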